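Selenium-linked vanillylamides: dienyl chain in place of octyl

This account rests on a few compounds, and the source may have more. Where it says the series, first, only, none or still open, it means among the compounds named here.

Compound 1 `CCCCCCCCCCCCCCCCCC(=O)NCc1ccc(O)c(OC)c1` is the saturated amide of the series. In an assay on HEK293 cells for antagonist activity at transient receptor potential cation channel subfamily V member 2 (Rattus norvegicus), read by fluorescence and calcium flux, with a stated time of 5 min (a lower number here means a stronger inhibitor, a higher number a weaker inhibitor), compound 1 gives > 10000 nM, which is a limit of the assay and not a number. Compound 2 `CCCCCCCCCCCCCCCC[Se]CCC(=O)NCc1ccc(O)c(OC)c1` carries the selenium-linked chain; in this assay compound 2 has "not determined" (no result reported), so no single number places it. Of the two values shown, compound 1 alone provides a figure, and that is the limit of > 10000 nM in this assay, at which 1 of the 2 values shown sits. For the measured compounds named here, compound 2 therefore stands without a value, with compound 1 as the only neighbour, and that neighbour is at the edge of what this assay reports.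

Compound 3 `CCCCC/C=C\C/C=C\CCCCCCCC[Se]CCC(=O)NCc1ccc(O)c(OC)c1` is the next member to be measured. It differs from compound 2 by deca-1,4-dien-1-yl in place of octyl on a saturated chain carbon, eight bonds along the chain from a selenium atom, the saturated octyl of compound 2 giving way to a deca-1,4-dien-1-yl chain on a saturated chain carbon, eight bonds along the chain from a selenium atom. Going by the values given here, no measured step between two compounds exists here to set the scale, so no direction beyond the scatter can be read from the numbers. For compound 3 the expected inhibitory concentration in this assay is 8000 nM, estimated to fall between 1500 nM and 30000 nM, with a real chance that only a limit is reported.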

Compound 3, half-maximal inhibitory concentration: 2300 nM
Compound 3: the middle estimate sits 3.5-fold (0.54 log units) above what was measured; measured number inside the range.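

No step can be read for compound 3: compound 2 has no number in this assay, and compound 1 differs from compound 3 in more than one place. Compound 1 stands at a limit of the assay: the limit of > 10000 nM in this assay, at which 1 of the 3 values shown sits. Open remains what the deca-1,4-dien-1-yl chain of compound 3 changes relative to the octyl of compound 2.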